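Replacing a pyridinyl amide by a pyridinylmethyl amide: expected lipophilicity

The source may hold more compounds than are shown below. What is called first, only, known or untested is meant among the compounds shown, and "the series" means these compounds.

Compound 1 `Cc1cc(C(N)=O)nn1Cc1cc(Cl)ccc1OCc1ccccc1`: in a physicochemical assay for lipophilicity, at pH 7.4 (a lower number here means a more polar compound, a higher number a more lipophilic compound), compound 1 gives 3.7.
Compound 2 `Cc1cc(C(=O)Nc2ccccn2)nn1Cc1cc(Cl)ccc1OCc1ccccc1`: in this assay compound 2 gives > 3.7, which is a limit of the assay and not a number.

Compound 2 therefore stands only at a limit in this assay; its true position is open. Within the data shown here, the single measured step, a number no lower from compound 1 to compound 2 (the limit leaves the size open), records a change that is no lower, its size unreadable, since one of the two values sits at the limit of > 3.7 in this assay, at which 1 of the 2 values shown sits.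

Compound 3 `Cc1cc(C(=O)NCc2ccncc2)nn1Cc1cc(Cl)ccc1OCc1ccccc1` differs from compound 2 in one place: (pyridin-4-yl)methyl in place of pyridin-2-yl on an amide-type nitrogen. Among the measured compounds shown here, no measured step covers this exchange of pyridin-2-yl for (pyridin-4-yl)methyl on the amide-type nitrogen. The step from compound 1 to compound 2 bears on it only by fixing the level from which compound 3 departs, and that level is known merely as a limit. The step expected here, a number at least 0.10 log units lower from compound 2 to compound 3 (that floor lies within the scatter), is estimated to be small, within the usual scatter, with no direction favoured. Compound 3 is expected to give 3.6 in this assay, with a range from 3 to 4.2.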

Compound 3, distribution coefficient: > 3.7
Compound 3 gave a limit, no number; the forecaster's own chance of this, stated with the estimate: 35%; middle value at least 0.10 log units away from the limit.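

In this assay compound 3 gives > 3.7 as a limit of the assay and not a number. With hydrogen on the amide-type nitrogen as the reference, (pyridin-4-yl)methyl now joins pyridin-2-yl in showing no fall, the reading being a number no lower from compound 1 to compound 3 (the limit leaves the size open) and so a direction without a size. The exchange of pyridin-2-yl for (pyridin-4-yl)methyl itself cannot be read, because compound 2 and compound 3 both stand at the same limit: (the limit of > 3.7 in this assay, at which 2 of the 3 values shown sit).

From the compounds shown here alone, how far compound 2 and compound 3 lie beyond that limit, and which of them would give the higher number, remains open. Also open, going by these compounds, is whether another group on the amide-type nitrogen, such as a chain ending in an amine or a carboxylic acid, would give a number that can be read in this assay rather than another limit.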